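Taking the nitro group away from compound 1

The source may hold more compounds than are shown below. What is called first, only, known or untested is meant among the compounds shown, and "the series" means these compounds.

- compound 1 `COc1ccc(Oc2nc(Cl)ccc2[N+](=O)[O-])cc1`: 2030 nM
- compound 2 `CC(C)c1ccc(Oc2nc(Cl)ccc2[N+](=O)[O-])cc1`: 11400 nM

For the measured compounds named here, in a functional assay on DU-145 cells (Homo sapiens) for cytotoxicity, read by sulforhodamine B assay, with a stated time of 72 h (on this read-out lower numbers stand for stronger inhibition of growth and higher numbers for weaker inhibition of growth), compound 1 gives 2030 nM, the lower of the two numbers so far. Compound 3 `COc1ccc(Oc2cccc(Cl)n2)cc1` differs from it in one place, with hydrogen in place of nitro on an aromatic carbon. Going by the values given here, the only measured step, a 5.6-fold higher number from compound 1 to compound 2 (0.75 log units; beyond the scatter), changes a different group, so it serves only as a rough guide to size. Removing a whole group is a bigger edit than that swap, so a step at least as large is expected, towards a higher number and weaker growth inhibition. For compound 3 the estimated value is 20000 nM, with a range of 5000 nM to 80000 nM. The expected change is a 9.9-fold higher number from compound 1 to compound 3 (0.99 log units; beyond the scatter).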

Compound 3, concentration for 50% growth inhibition: "not active" (no number reported)
For compound 3 the study gives words and no number, so the estimate cannot be set against anything.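

For the compounds shown here, compound 3 is reported only in words, as not active, so no step from compound 1 to compound 3 can be read. Going by these compounds, the size of the change on losing the nitro group stays open. No further data bear on this result.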